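Swapping the Anilino Ring of Compound 2 for an Indole

The source may report more compounds than this note shows. Statements on the series, on what has been measured and on what is new or still open speak of the compounds shown alone.

Compound 2 `COc1ccc(N/C=C\C(=O)c2nc(-c3ccc(F)cc3)n3ccccc23)cc1OC` carries a fluoro group where compound 1 `COc1ccc(N/C=C\C(=O)c2nc(-c3ccc(C(F)(F)F)cc3)n3ccccc23)cc1OC` carries trifluoromethyl. In a functional assay on HCT-116 cells (Homo sapiens) for cytotoxicity, read by MTT assay, with a stated time of 48 h (a higher number here means a weaker inhibitor, a lower number a stronger inhibitor), compound 1 gives only a limit, > 30000 nM. In this assay compound 2 likewise gives only a limit, > 30000 nM. The step that the two limits leave unreadable from compound 1 to compound 2 therefore cannot be read, since both values sit at the limit of > 30000 nM in this assay, at which 2 of the 2 values shown sit. Compound 3 `Cc1cc2cc(N/C=C\C(=O)c3nc(-c4ccc(F)cc4)n4ccccc34)ccc2[nH]1` differs from compound 2 by 2-methyl-1H-indol-5-yl in place of 3,4-dimethoxyphenyl on an amine nitrogen. For the measured compounds named here, no measured step bears on this change. For compound 3 the expected step is therefore an at least 1.5-fold lower number from compound 2 to compound 3 (0.17 log units; that floor lies within the scatter), a guess from a weak starting point. Compound 3 is estimated at 20000 nM, within 3000 nM to 60000 nM.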

Compound 3, half-maximal inhibitory concentration: > 30000 nM
Compound 3 ended at the assay's limit; the forecaster's own chance of this, stated with the estimate: 60%; middle value at least 1.5-fold (0.17 log units) from the limit.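

Compound 2 and compound 3 both give only a limit in this assay, so no step between them can be read: the limit of > 30000 nM in this assay, at which 3 of the 3 values shown sit.

The compounds shown leave open whether 2-methyl-1H-indol-5-yl or 3,4-dimethoxyphenyl on the amine nitrogen gives the lower number.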